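Trifluoromethyl for Fluoro on the Aniline of Compound 3

The source may hold more compounds than are shown below. What is called first, only, known or untested is meant among the compounds shown, and "the series" means these compounds.

Among the compounds with values here, compound 3 `COc1cc(-c2nn(-c3ccccc3)cc2C(=O)/C=C\Nc2ccc(F)cc2)cc(OC)c1OC` is the only member of this small set with a measured number in a functional assay on PC-3 cells (Homo sapiens) for antiproliferative activity, read by MTT assay, with a stated time of 48 h (a lower number here means a stronger inhibitor, a higher number a weaker inhibitor), where compound 3 gives 7700 nM. Compound 1 `O=C(/C=C\Nc1ccc(C(F)(F)F)cc1)c1cn(-c2ccccc2)nc1-c1ccc(F)cc1` reaches only the limit of the assay, > 50000 nM in this assay. Compound 2 `COc1ccc(-c2nn(-c3ccccc3)cc2C(=O)/C=C\Nc2ccc(C(F)(F)F)cc2)cc1` likewise reaches only the limit, > 50000 nM in this assay. Within the data shown here, the one measured step, a step that the two limits leave unreadable from compound 1 to compound 2, cannot be read because both values sit at the limit of > 50000 nM in this assay, at which 2 of the 3 values shown sit.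

Compound 4 `COc1cc(-c2nn(-c3ccccc3)cc2C(=O)/C=C\Nc2ccc(C(F)(F)F)cc2)cc(OC)c1OC` differs from compound 3 by trifluoromethyl in place of fluoro on an aromatic carbon. Among the measured compounds shown here, no measured pair compares fluoro with trifluoromethyl at this position, so the direction of this step rests on what compounds 1 and 2 show. Both carry the trifluoromethyl aniline that compound 4 acquires, and both stop at the limit, while compound 3 with the fluoro aniline gives a number. The step is therefore expected to weaken activity beyond the usual scatter, a 3.2-fold higher number from compound 3 to compound 4 (0.51 log units; beyond the scatter), with a fair chance that only a limit is reported. Compound 4 is expected to give about 25000 nM in this assay, within 6000 nM to 60000 nM.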

Compound 4, half-maximal inhibitory concentration: > 50000 nM
Compound 4 ended at the assay's limit; the forecaster's own chance of this, stated with the estimate: 40%; at least 2.0-fold (0.30 log units) between middle value and limit.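

In this assay, within the data shown here, the first measured pair at this position, 4-fluorophenyl to 4-(trifluoromethyl)phenyl, gives an at least 6.4-fold higher number from compound 3 to compound 4 (0.81 log units; beyond the scatter), and this size is only a lower bound. Compound 4 gives a limit of the assay and not a number: the limit of > 50000 nM in this assay, at which 3 of the 4 values shown sit. The steps to compound 4 from compound 1 and from compound 2 cannot be read, but compound 4 shows that the 3,4,5-trimethoxyphenyl group does not by itself preserve a measurable number once trifluoromethyl enters.

Going by these compounds, how far the true value of compound 4 lies past the limit stays open. So does whether the measurable activity is specific to fluoro, since the compounds shown do not tell how a chlorine, a nitrile or a dimethylamino group would read at this position.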